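Sulfonamide nitrogen substituent swap on a hydroxamic acid

The compounds below may be only part of what the source reports. "The series", "measured", "known", "first", "only" and "open" are said of these compounds alone.

Compound 1 `O=C(NO)c1ccc(CN(C2CC2)S(=O)(=O)c2cc(F)c(F)c(F)c2F)cc1` — 8.5 nM
Compound 2 `CC(C)N(Cc1ccc(C(=O)NO)cc1)S(=O)(=O)c1c(F)c(F)c(F)c(F)c1F` — 4.32 nM

In an assay on Sf9 cells for inhibition of protein deacetylase HDAC6 (Homo sapiens), read by fluorescence and mobility shift assay (on this read-out lower numbers stand for stronger inhibition and higher numbers for weaker inhibition), compound 1 gives 8.5 nM and compound 2 gives 4.32 nM, two numbers that sit within the scatter of one another; compound 1 thus stands at one end of a pair that the measurement cannot separate. Compound 3 `CC(C)CN(Cc1ccc(C(=O)NO)cc1)S(=O)(=O)c1cc(F)c(F)c(F)c1F` differs from compound 1 by isobutyl in place of cyclopropyl on a sulfonamide nitrogen. Among the compounds with values here, no measured pair shows what this change does. With both measured values close together, compound 3 is expected to stay in the same region, so the step from a 1.2-fold lower number from compound 1 to compound 3 (0.08 log units; within the scatter) is estimated as none beyond the scatter. Compound 3 is therefore expected near 7 nM, in a range from 2.5 nM to 20 nM.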

Compound 3, half-maximal inhibitory concentration: 24.6 nM
For compound 3 the middle estimate is 3.5-fold (0.55 log units) below the measured one; measured number outside the range, above it.
By their numbers in this assay, from the lowest: compounds 2 and 1 (each within the scatter of the next); then compound 3.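

In this assay, the sulfonamide nitrogen does not tolerate every substituent equally: isobutyl in place of cyclopropyl gives a 2.9-fold higher number from compound 1 to compound 3 (0.46 log units; beyond the scatter), a modest weakening and the only step at this position shown here. A single pair carries this finding, so it describes this one change and no general trend. No available measurement explains the step. Going by these compounds, it remains open whether the loss tracks the missing ring or the branched chain, and how methyl or a 2-aminoethyl chain would read on this nitrogen.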